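The source may report more compounds than this note shows. Statements on the series, on what has been measured and on what is new or still open speak of the compounds shown alone.

Measured compounds:
Compound 1 `CCC(C)(C)Cc1c[nH]c(CCc2ccc(-c3ccncc3)cc2)n1`: in a functional assay on HEK293 cells for agonist activity at Bombesin receptor subtype-3 (Homo sapiens), read by luminescence and calcium flux, with a stated time of 10 min (on this read-out lower numbers stand for an effect already at smaller amounts and higher numbers for an effect only at larger amounts of compound), compound 1 gives 95 nM.
Compound 2 `CCC(C)(C)Cc1c[nH]c(CCc2ccc(-c3cccnc3C(=O)O)cc2)n1`: in this assay compound 2 gives 95 nM.

On these numbers compound 2 stands level with compound 1 at the digits shown; the step of no change at the digits printed from compound 1 to compound 2 (within the scatter) lies within the scatter. Compound 3 `CCC(C)(C)Cc1c[nH]c(CCc2ccc(-c3ccns3)cc2)n1` has not yet been measured. It differs from compound 2 by 1,2-thiazol-5-yl in place of 2-carboxypyridin-3-yl on an aromatic carbon, the change sitting on an aromatic carbon of the six-membered ring of carbon only, para to a large group. Going by the values given here, the one measured step that bears on this position is no change at the digits printed from compound 1 to compound 2 (within the scatter), in which one six-membered aromatic ring with a hetero atom gave way to another without any movement beyond the scatter. That step is only a loose guide here. Among the compounds with values here, no measured pair exchanges a six-membered aromatic ring for a five-membered one at this place. On this basis the step is expected to be small, with a 1.3-fold higher number from compound 2 to compound 3 (0.10 log units; within the scatter) lying inside the usual scatter. Compound 3 is therefore estimated at 120 nM, with a range from 40 nM to 400 nM.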

Compound 3, half-maximal effective concentration: 102 nM
The estimate for compound 3 lay 1.2-fold (0.07 log units) above the measured number; the measured number falls inside the stated range.
By their numbers in this assay, from the lowest: compounds 1, 2 and 3 (each within the scatter of the next).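

In this assay the five-membered 1,2-thiazol-5-yl ring, on an aromatic carbon of the six-membered ring of carbon only and para to a large group, gives a 1.1-fold higher number from compound 2 to compound 3 (0.03 log units; within the scatter) against 2-carboxypyridin-3-yl and a 1.1-fold higher number from compound 1 to compound 3 (0.03 log units; within the scatter) against pyridin-4-yl. Going by these compounds alone, the earlier pair had only exchanged one six-membered aromatic ring with 1 hetero atom for another, so this is the first measured case at this place in which ring size and hetero atom count differ, and the result stays within the scatter. The group entering for 2-carboxypyridin-3-yl has 5 heavy atoms in place of 9 and 0 hydrogen-bond donors, and together with compound 1 this shows that a carboxylic acid on the ring is not needed to reach this level among these three compounds.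

The compounds shown leave open whether an amine, a longer chain or a plain phenyl ring at this carbon would stay within the scatter of these three. They also leave open whether any group here moves the number beyond the scatter at all. No further data are at hand that could account for these three compounds lying so close together.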